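From Methyl to a Carbamoyl Chain: Estimating Compound 4

The source may hold more compounds than are shown below. What is called first, only, known or untested is meant among the compounds shown, and "the series" means these compounds.

Measured compounds in a functional assay on HT-29 cells (Homo sapiens) for inhibition; a higher number here means a weaker inhibitor, a lower number a stronger inhibitor:
Compound 1 `Cc1cnc(CN2CC(=O)N(CC(C)C)c3c(Cl)nc(N)nc32)c(C)c1Br` gives 140 nM.
Compound 2 `COc1c(C)cnc(CN2c3nc(N)nc(Cl)c3NC(=O)[C@H]2C)c1C` gives 470 nM.
Compound 3 `COc1c(C)cnc(CN2CC(=O)N(C(C)C)c3c(Cl)nc(N)nc32)c1C` gives 60 nM.

Among these three, compound 3 holds the lowest number in this assay; its gaps to compound 1 and to compound 2 both lie beyond the usual scatter, so it is the strongest inhibitor of the set as measured. Compound 4 `COc1c(C)cnc(CN2CC(=O)N(C(C)C(=O)NCCN(C)C)c3c(Cl)nc(N)nc32)c1C` has not yet been measured. It differs from compound 3 in one place: (2-(dimethylamino)ethyl)carbamoyl in place of methyl on a saturated chain carbon bound to an amide-type nitrogen in a ring and a saturated chain carbon. Going by the values given here, the change adds a sizable chain carrying a hydrogen-bond donor and two acceptors where a single carbon stood, and nothing among the measured compounds shows what such an addition does in this assay. Among the compounds with values here, with no comparable step on record, the direction is uncertain; a moderate loss is expected, and the step from compound 3 to compound 4 is estimated as a 2.5-fold higher number from compound 3 to compound 4 (0.40 log units; beyond the scatter). Compound 4 is therefore expected to give about 150 nM in this assay, with a plausible range from 40 nM to 600 nM.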

Compound 4, half-maximal inhibitory concentration: 100 nM
Compound 4: the middle estimate sits 1.5-fold (0.18 log units) above what was measured, and the stated range covers the measured number.
By their numbers in this assay, from the lowest: compounds 3, 4 and 1 (each within the scatter of the next, the first and the last beyond it); then compound 2.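

Exchanging methyl for (2-(dimethylamino)ethyl)carbamoyl on a saturated chain carbon bound to an amide-type nitrogen in a ring and a saturated chain carbon gives, in this assay, a 1.7-fold higher number from compound 3 to compound 4 (0.22 log units; within the scatter), so compound 3 and compound 4 cannot be told apart. Going by these compounds alone, this position therefore accepts a much larger chain without a loss beyond the scatter, something the earlier compounds could not show, since no two of them differed in one place only. Nothing at hand explains this tolerance.

On these data alone, this single step does not separate the parts of the new chain, so it remains open whether the carbamoyl alone, without the dimethylamino end, would read the same. As far as these compounds go, a carboxylic acid, a morpholine or a longer chain at this carbon also remains open.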